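The source may hold more compounds than are shown below. What is called first, only, known or untested is meant among the compounds shown, and "the series" means these compounds.

Measured so far:
Compound 1 `ClCc1ccc(Cn2cnc3c(Cl)ncnc32)cc1`, in a functional assay on MDA-MB-435 cells (Homo sapiens) for cytotoxicity, read by sulforhodamine B assay, with a stated time of 48 h (a lower number here means a stronger inhibitor of growth, a higher number a weaker inhibitor of growth), gives 4360 nM.
Compound 2 `Nc1nc(Cl)c2ncn(Cc3ccc(CCl)cc3)c2n1`, in this assay, gives 42700 nM.

Among the measured compounds shown here, of these two numbers, compound 2 stands highest; its only neighbour is compound 1, and the single measured step, a 9.8-fold higher number from compound 1 to compound 2 (0.99 log units; beyond the scatter), lies between them. That step shows how much the number rose when amino replaced hydrogen on the aromatic carbon of the shared core.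

Compound 3 `ClCc1ccc(Cn2cnc3c(Cl)nc(Cl)nc32)cc1` is not yet measured. It differs from compound 2 in one place: chloro in place of amino on an aromatic carbon. Chloro is not hydrogen, and no measured pair covers an exchange of amino for chloro, but the group that leaves is the very one whose arrival gave a 9.8-fold higher number from compound 1 to compound 2 (0.99 log units; beyond the scatter). Its removal in compound 3 is expected to undo part of that rise, without any basis for assuming the full amount. In this assay compound 3 is therefore expected to show a 4.7-fold lower number from compound 2 to compound 3 (0.68 log units; beyond the scatter), a lower number than compound 2. The estimate for compound 3 is 9000 nM, within a range from 2500 nM to 35000 nM.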

Compound 3, concentration for total growth inhibition: 25100 nM
Compound 3: middle estimate off by 2.8-fold (0.45 log units), on the low side, and the stated range covers the measured number.
By their numbers in this assay, from the lowest: compound 1; then compounds 3 and 2 (each within the scatter of the next).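

In this assay, the aromatic carbon between two ring nitrogen atoms has now carried hydrogen, amino and chloro, and a 1.7-fold lower number from compound 2 to compound 3 (0.23 log units; within the scatter) shows that amino and chloro cannot be told apart at this position. Compared with hydrogen, chloro gives a 5.8-fold higher number from compound 1 to compound 3 (0.76 log units; beyond the scatter) and amino gives a 9.8-fold higher number from compound 1 to compound 2 (0.99 log units; beyond the scatter), so the earlier result was not unique to amino: in these three compounds, both groups give a weaker inhibitor of growth than the hydrogen of compound 1. The data offer no measured explanation for why amino and chloro read alike or why hydrogen stands apart.

The compounds shown leave open whether a methyl group, a methoxy group or a larger amine at this position would read like hydrogen or like amino and chloro. They also leave open whether the same picture would hold if the chloro group meta to this position were replaced by another group, such as an amine.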